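This account rests on a few compounds, and the source may have more. Where it says the series, first, only, none or still open, it means among the compounds named here.

Measured compounds:
compound 1, `NCCCOc1ccccc1C(=O)N(Cc1ccc(OCCCN=C(N)N)cc1)c1nc2ccc(Oc3ccccc3)cc2s1` — 3080 nM
compound 2, `NCCCOc1ccccc1C(=O)N(Cc1ccc(OCCCN=C(N)N)cc1)c1nc2ccc(Oc3ccc(O)cc3)cc2s1` — 1780 nM
compound 3, `NCCCOc1ccccc1C(=O)Nc1nc2ccc(Oc3ccccc3)cc2s1` — > 100000 nM

Among the measured compounds shown here, in an assay on isolated protein for inhibition of Voltage-dependent N-type calcium channel subunit alpha-1B (Rattus norvegicus) (a lower number here means that less compound is needed, a higher number that more compound is needed for the effect), the only change measured in one place is a 1.7-fold lower number from compound 1 to compound 2 (0.24 log units; within the scatter). Compound 3 stands at the limit of > 100000 nM in this assay, at which 1 of the 3 values shown sits, so for compound 3 only a limit is known. Compound 4, `NC(N)=NCCCOc1ccccc1C(=O)Nc1nc2ccc(Oc3ccccc3)cc2s1`, differs from compound 3 by a group of 4 heavy atoms (1 carbon, 3 nitrogen; no ring) in place of one nitrogen atom, on a saturated chain carbon, three bonds along the chain from an oxygen on an aromatic ring. For the measured compounds named here, no measured step covers this change, and the shift from compound 1 to compound 2 concerns another position. There is thus no ground to expect a change beyond the scatter, and compound 4 is estimated to remain at or near the limit, at 100000 nM (range 20000 nM to 300000 nM), an expected step of a number no higher from compound 3 to compound 4 (the limit leaves the size open).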

Compound 4, half-maximal effective concentration: 33000 nM
Beside the measured number, compound 4's estimate is 3.0-fold (0.48 log units) above it; low and high end bracket the measured number.
By their numbers in this assay, from the lowest: compounds 2 and 1 (each within the scatter of the next); then compound 4. At a limit, above all of these: compound 3.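

In this assay, this chain position responds to what stands at its end: the group of 4 heavy atoms (1 carbon, 3 nitrogen; no ring) in place of amino gives an at least 3.0-fold lower number from compound 3 to compound 4 (0.48 log units; beyond the scatter). The earlier compounds shown here all carried amino here, so they could not show this. The full size of the step stays open, since compound 3 stands at a limit of the assay: the limit of > 100000 nM in this assay, at which 1 of the 4 values shown sits.

As far as these compounds go, whether a dimethylamine, a urea or a carboxylic acid at this position would also lower the number remains open. So does the effect of a longer chain.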